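The source may hold more compounds than are shown below. What is called first, only, known or untested is meant among the compounds shown, and "the series" means these compounds.

Two compounds in this set have a number. The first, compound 1 `O=c1[nH]c(=O)n([C@H]2C[C@H](O)[C@@H](CO)O2)cc1/C=N/O`, carries a sugar and a pyrimidine core bearing a small three-atom group of one carbon, one nitrogen and one oxygen; in an ADME assay on L1210/0 cells (Mus musculus) for cytotoxicity, with a stated time of 48 h (on this read-out higher numbers stand for weaker inhibition and lower numbers for stronger inhibition), compound 1 gives 15500 nM. The second, compound 2 `O=C1O/C(=C/Cn2cnc3c(-n4cccc4)ncnc32)C(OCc2ccccc2)=C1OCc1ccccc1`, is built on a quite different scaffold, and in this assay compound 2 gives 110000 nM. Compound 1 thus shows the lower of the two numbers, and its gap to compound 2 lies beyond the usual scatter.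

Compound 3 `O=c1[nH]c(=O)n([C@H]2C[C@H](O)[C@@H](CO)O2)cc1C#Cc1ccccc1` keeps the core and sugar of compound 1 and changes only one spot: a group of 8 heavy atoms (8 carbon; one six-membered aromatic ring of carbon only) in place of a group of 3 heavy atoms (1 carbon, 1 nitrogen, 1 oxygen; no ring), on an aromatic carbon. The entering 2-phenylethynyl group sits on the same aromatic carbon, two atoms from the ring nitrogen.

Going by the values given here, no step between two measured compounds of this kind is available here, so the effect of this exchange is open. The expectation is a modest move in this assay, in no firm direction and possibly not beyond the scatter, so that the step from compound 1 to compound 3 is estimated at a 1.6-fold lower number from compound 1 to compound 3 (0.19 log units; within the scatter). Compound 3 is therefore expected to give about 10000 nM, within a range of 2000 nM to 80000 nM.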

Compound 3, half-maximal inhibitory concentration: > 200000 nM
Compound 3: no number, only a limit; the forecaster's own chance of this, stated with the estimate: 20%; middle value at least 20-fold (1.30 log units) from the limit.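

This exchange on the aromatic carbon is far from neutral in this assay: putting the 2-phenylethynyl group in place of the small group of one carbon, one nitrogen and one oxygen gives an at least 12-fold higher number from compound 1 to compound 3 (1.11 log units; beyond the scatter). So with the sugar and core held constant, this one position alone can carry the read-out from a measurable inhibition to none that reaches a number, at least for this pair. Compound 3 has only a limit, > 200000 nM, not a true number, and the step can therefore be read in one direction only, with its full size unknown: the limit of > 200000 nM in this assay, at which 1 of the 3 values shown sits.

The pair cannot tell whether the phenyl ring, the triple bond or the loss of the original group accounts for the change, since all three differ at once. Where a plain ethynyl, a methyl, an aminomethyl or a carboxylic acid on this same carbon would fall relative to compound 1 and compound 3 remains open, as does whether this change would act the same way on the scaffold of compound 2.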